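Phenyl in Place of Ethyl on the Ring Nitrogen

This account rests on a few compounds, and the source may have more. Where it says the series, first, only, none or still open, it means among the compounds named here.

Of the compounds shown here, three have so far been measured in a functional assay on the whole organism (strain albino) for inhibition, with Rattus norvegicus as the target, read by paw edema, with a stated time of 4 h, at a dose of 0.28 mmol/kg by the oral route; on this read-out higher numbers stand for more inhibition at the one dose given (going by the name of the read-out) and lower numbers for less inhibition. Compound 1, `CCn1c(SCC(=O)c2ccccc2)nnc1-c1cc(OC)c(OC)c(OC)c1`, gives 72%. Compound 2, `CCn1c(SCC(=O)c2ccccc2)nnc1-c1ccc(OC)c(OC)c1`, gives 73%, and compound 3, `CCn1c(SC/C(=N/O)c2ccccc2)nnc1-c1ccc(OC)cc1`, gives 78%. Compound 1 therefore carries the lowest of the three numbers, yet its gap to compound 2 and its gap to compound 3 both lie within the usual scatter, so the three values cannot be told apart. Among the compounds with values here, the single step between compounds that differ in one place is a number 1 percentage points higher from compound 1 to compound 2 (within the scatter), which came with hydrogen in place of methoxy on an aromatic carbon.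

Compound 4, `COc1cc(-c2nnc(SCC(=O)c3ccccc3)n2-c2ccccc2)cc(OC)c1OC`, is not yet measured. It differs from compound 1 in one place: phenyl in place of ethyl on an aromatic nitrogen. Within the data shown here, no measured step touches this ring nitrogen; the one step known concerns a methoxy group on an aromatic carbon and stayed within the scatter, so it does not speak to the present change. With nothing pointing either way, no step beyond the scatter is expected, and the estimate for compound 4 is 70%, with a range from 55% to 85%. This amounts to an expected step of a number 2 percentage points lower from compound 1 to compound 4 (within the scatter).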

Compound 4, a percentage reported as inhibition, in the whole organism at one dose (the size of the read-out at that dose, not a potency): 73%
Beside the measured number, compound 4's estimate is 3 percentage points below it; the measured number falls inside the stated range.
By their numbers in this assay, from the lowest: compounds 1, 2, 4 and 3 (each within the scatter of the next).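

Putting phenyl in place of ethyl on the aromatic nitrogen gives a number 1 percentage points higher from compound 1 to compound 4 (within the scatter) in this assay. Within the data shown here, this is the first look at this ring nitrogen, and it shows that a group of 6 heavy atoms with its own six-membered aromatic ring can stand there, next to two ring atoms that each bear a large group, and leave compound 4 impossible to tell apart from compound 1 at this single oral dose. No measurement at hand bears on this result, so what lies behind it stays unknown.

The compounds shown carry only ethyl or phenyl on this nitrogen, so it remains open whether a longer chain such as butyl, a benzyl group or a chain ending in an amine would also fall within the scatter of compound 1, or would instead move the number clearly in either direction. Going by these compounds, it is also open whether phenyl on the nitrogen would give a similar result alongside the other groups that compound 2 and compound 3 carry, and whether a comparison across several doses would separate compound 1 from compound 4.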